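Replacing pyrazin-2-yl with 1,2,4-oxadiazol-3-yl on the shared core

The source may hold more compounds than are shown below. What is called first, only, known or untested is meant among the compounds shown, and "the series" means these compounds.

Measured in an ADME assay on the whole organism (plasma, strain 129/SvEvBrd x C57BL/6) for pharmacokinetics, with Mus musculus as the target, at a dose of 10 mg/kg by the oral route; a lower number here means less compound in the circulation, a higher number more compound in the circulation at the dose given:
- compound 1 `CC(O)c1nc([C@@H](O)[C@H](O)[C@H](O)CO)c[nH]1`: 10300 ng.h/mL
- compound 2 `Cc1nc(-c2nc([C@@H](O)[C@H](O)[C@H](O)CO)c[nH]2)cs1`: 1970 ng.h/mL
- compound 3 `OC[C@@H](O)[C@@H](O)[C@H](O)c1c[nH]c(-c2cnccn2)n1`: 1250 ng.h/mL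

Compound 3 stands level with compound 2 and well under compound 1 on these numbers. Compound 4 `OC[C@@H](O)[C@@H](O)[C@H](O)c1c[nH]c(-c2ncon2)n1` has 1,2,4-oxadiazol-3-yl in place of pyrazin-2-yl on an aromatic carbon. Going by the values given here, the closest precedent is one aromatic ring exchanged for another, with a 1.6-fold lower number from compound 2 to compound 3 (0.20 log units; within the scatter) as its size. The larger steps, a 5.2-fold lower number from compound 1 to compound 2 (0.72 log units; beyond the scatter) and an 8.2-fold lower number from compound 1 to compound 3 (0.92 log units; beyond the scatter), both remove 1-hydroxyethyl, a change that compound 4 does not repeat against compound 3. No 1,2,4-oxadiazol-3-yl compound has been measured, so this rests on one precedent. No step beyond the scatter is therefore expected in this assay. The estimated change is a 1.2-fold higher number from compound 3 to compound 4 (0.08 log units; within the scatter). Compound 4 is estimated at 1500 ng.h/mL, with an expected range of 600 ng.h/mL to 3800 ng.h/mL.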

Compound 4, area under the concentration-time curve: 820 ng.h/mL
The estimate for compound 4 lay 1.8-fold (0.26 log units) above the measured number; the range from low to high includes it.
By their numbers in this assay, from the lowest: compounds 4, 3 and 2 (each within the scatter of the next, the first and the last beyond it); then compound 1.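

In this assay a five-membered aromatic ring at this position gives a 1.5-fold lower number from compound 3 to compound 4 (0.18 log units; within the scatter) and so, like the earlier exchange of one aromatic ring for another, this one stays within the scatter. The same ring also gives a 2.4-fold lower number from compound 2 to compound 4 (0.38 log units; beyond the scatter) and a 13-fold lower number from compound 1 to compound 4 (1.10 log units; beyond the scatter) so the 2-methyl-1,3-thiazol-4-yl and 1,2,4-oxadiazol-3-yl compounds now stand apart, while the 1-hydroxyethyl compound remains above every aromatic ring shown. Nothing measured here explains these differences. As far as these compounds go, whether an aminomethyl group or a longer hydroxyalkyl chain at this position would match 1-hydroxyethyl remains open.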